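From 4-methoxyphenyl to 2-methylphenyl: a small step expected

The source may report more compounds than this note shows. Statements on the series, on what has been measured and on what is new or still open speak of the compounds shown alone.

In a functional assay on MCF7 cells (Homo sapiens) for inhibition, read by MTT assay, with a stated time of 72 h (a higher number here means a weaker inhibitor, a lower number a stronger inhibitor), compound 1 `Cc1ccc(C(C)C)c(OCc2cn(-c3ccccc3)nn2)c1` gives 29900 nM. Compound 2 `Cc1ccc(C(C)C)c(OCc2cn(-c3ccccc3Cl)nn2)c1` gives 15600 nM. Compound 3 `COc1ccc(-n2cc(COc3cc(C)ccc3C(C)C)nn2)cc1` gives 25400 nM, a number within the usual scatter of both of the others, so these data set no order among the three.

Compound 4 `Cc1ccc(C(C)C)c(OCc2cn(-c3ccccc3C)nn2)c1` has 2-methylphenyl in place of 4-methoxyphenyl on an aromatic nitrogen. Among the measured compounds shown here, three measured steps bear on this change. Chloro in place of hydrogen on an aromatic carbon gives a 1.9-fold lower number from compound 1 to compound 2 (0.28 log units; within the scatter). Adding a methoxy group gives a 1.2-fold lower number from compound 1 to compound 3 (0.07 log units; within the scatter). The swap on the same aromatic nitrogen, 4-methoxyphenyl in place of 2-chlorophenyl, gives a 1.6-fold higher number from compound 2 to compound 3 (0.21 log units; within the scatter). For the measured compounds named here, none of these steps leaves the scatter, although no measured compound yet carries 2-methylphenyl. The closest match by name is the 2-chlorophenyl of compound 2, at 15600 nM, so the estimate leans slightly toward that value. No step beyond the scatter is therefore expected in this assay. The expected change is a 1.3-fold lower number from compound 3 to compound 4 (0.10 log units; within the scatter), a small estimated shift toward a lower number. For compound 4 the estimate is 20000 nM, with an expected range from 10000 nM to 40000 nM.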

Compound 4, half-maximal inhibitory concentration: 6170 nM
Compound 4: middle estimate off by 3.2-fold (0.51 log units), on the high side, and the stated range ends above it.
By their numbers in this assay, from the lowest: compound 4; then compounds 2, 3 and 1 (each within the scatter of the next).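

Among the compounds shown here, compound 4 gives the first steps beyond the scatter in this assay: methyl in place of hydrogen on the aromatic carbon gives a 4.8-fold lower number from compound 1 to compound 4 (0.69 log units; beyond the scatter), and replacing the whole 4-methoxyphenyl with 2-methylphenyl gives a 4.1-fold lower number from compound 3 to compound 4 (0.61 log units; beyond the scatter). Chloro and methyl at this place are not interchangeable, as methyl in place of chloro gives a 2.5-fold lower number from compound 2 to compound 4 (0.40 log units; beyond the scatter), so 2-chlorophenyl proves a poor stand-in for 2-methylphenyl, and the identity of the small group on this aromatic ring matters in this cell assay. No available measurement accounts for this difference between methyl and chloro.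

The compounds shown do not say whether the methyl group must sit where it does in 2-methylphenyl, which a comparison with 4-methylphenyl would test, or whether a larger or different group such as 2-ethylphenyl or 2-aminophenyl would lower the number further. With only one cell line and one read-out here, they also leave open whether the step from compound 1 to compound 4 would hold in other cells.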